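The source may report more compounds than this note shows. Statements on the series, on what has been measured and on what is new or still open speak of the compounds shown alone.

Measured so far in a functional assay on PC-3 cells (Homo sapiens) for cytotoxicity, read by MTT assay, with a stated time of 48 h; on this read-out lower numbers stand for stronger inhibition and higher numbers for weaker inhibition:
compound 1 `[O-][n+]1nc(NCc2ccccc2)[n+]([O-])c2ccccc21` – 10700 nM
compound 2 `[O-][n+]1nc(NCc2ccccc2Cl)[n+]([O-])c2ccccc21` – 10600 nM
compound 3 `CCNc1n[n+]([O-])c2ccccc2[n+]1[O-]` – 13300 nM

Compound 3 carries the high end of the three numbers, but a 1.2-fold higher number from compound 1 to compound 3 (0.09 log units; within the scatter) and a 1.3-fold higher number from compound 2 to compound 3 (0.10 log units; within the scatter) are both within the scatter, so the three compounds are not separated by this assay. The unmeasured compound 4 `[O-][n+]1nc(NC2CCCCC2)[n+]([O-])c2ccccc21` differs from compound 3 by cyclohexyl in place of ethyl on a nitrogen on an aromatic ring. Going by the values given here, two measured steps touch the same nitrogen substituent: a 1.2-fold higher number from compound 1 to compound 3 (0.09 log units; within the scatter) and a 1.3-fold higher number from compound 2 to compound 3 (0.10 log units; within the scatter), each within the scatter, so trading a small alkyl for a larger arylmethyl on that nitrogen has not moved the read-out. The remaining step, a 1.0-fold lower number from compound 1 to compound 2 (0.00 log units; within the scatter), is also within the scatter. Among the compounds with values here, no measured step distinguishes a saturated ring from a chain on that nitrogen, so the change to cyclohexyl is untested; on the steps available, no step beyond the scatter is expected. Compound 4 is therefore estimated at 11000 nM, with a range of 4500 nM to 27000 nM. The expected step is a 1.2-fold lower number from compound 3 to compound 4 (0.08 log units; within the scatter), within the scatter.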

Compound 4, half-maximal inhibitory concentration: 10500 nM
Compound 4: the middle estimate sits 1.0-fold (0.02 log units) above what was measured; measured number inside the range.
By their numbers in this assay, from the lowest: compounds 4, 2, 1 and 3 (each within the scatter of the next).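

In this assay, cyclohexyl in place of ethyl on a nitrogen on an aromatic ring gives a 1.3-fold lower number from compound 3 to compound 4 (0.10 log units; within the scatter), so this nitrogen carries a six-membered non-aromatic ring of carbon only, with 6 heavy atoms in place of 2, and the read-out stays within the scatter. The earlier steps shown here at this nitrogen exchanged only methyl with phenyl or 2-chlorophenyl on a saturated chain carbon, whereas this step tests a saturated ring and shows the same lack of separation. No supporting data bear on why the read-out does not separate these compounds.

Open, as far as these compounds go, is whether a primary amine or a carboxylic acid on the substituent, or a longer chain such as octyl, would move the number. Also open, from the compounds shown here alone, is whether any substituent on the shared core would give a step beyond the scatter.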